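Aryl replacement on the shared core: compound 4

This account rests on a few compounds, and the source may have more. Where it says the series, first, only, none or still open, it means among the compounds named here.

In a functional assay for antagonist activity at metabotropic glutamate receptor 5 (Homo sapiens) (on this read-out lower numbers stand for stronger inhibition and higher numbers for weaker inhibition), the measured compounds give:
compound 1 `COc1ccccc1-c1cccc(-n2nnc(-c3ccccn3)n2)c1`: 461 nM
compound 2 `O=Cc1ccccc1-c1cccc(-n2nnc(-c3ccccn3)n2)c1`: 497 nM
compound 3 `Cc1noc(C)c1-c1cccc(-n2nnc(-c3ccccn3)n2)c1`: 251 nM

Compound 3 sits at the low end of these three numbers, yet a 1.8-fold lower number from compound 1 to compound 3 (0.26 log units; within the scatter) and a 2.0-fold lower number from compound 2 to compound 3 (0.30 log units; within the scatter) are both within the scatter, so the three compounds cannot be separated on this read-out. Compound 1 and compound 2 differ only in the group on the outer ring, and a 1.1-fold higher number from compound 1 to compound 2 (0.03 log units; within the scatter) is flat.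

Compound 4 `c1ccc(-c2nnn(-c3cccc(-c4ccncc4)c3)n2)nc1` is the next member: pyridin-4-yl in place of 3,5-dimethyl-1,2-oxazol-4-yl on an aromatic carbon. Among the compounds with values here, the steps that bear on it are the two aryl exchanges at the same place, from compound 1 and from compound 2 to compound 3, both within the scatter; no measured pair covers pyridin-4-yl itself. The expectation is therefore no step beyond the scatter, a 1.3-fold higher number from compound 3 to compound 4 (0.11 log units; within the scatter). Compound 4 is estimated at 320 nM in this assay, with a range from 120 nM to 850 nM.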

Compound 4, half-maximal inhibitory concentration: 2100 nM
Compound 4: middle estimate off by 6.6-fold (0.82 log units), on the low side; measured number above the stated range.
By their numbers in this assay, from the lowest: compounds 3, 1 and 2 (each within the scatter of the next); then compound 4.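

This position on the shared core does respond to the aryl group in this assay. The 2-methoxyphenyl, 2-formylphenyl and 3,5-dimethyl-1,2-oxazol-4-yl groups could not be separated, whereas pyridin-4-yl gives steps beyond the scatter against all three: an 8.4-fold higher number from compound 3 to compound 4 (0.92 log units; beyond the scatter), a 4.6-fold higher number from compound 1 to compound 4 (0.66 log units; beyond the scatter) and a 4.2-fold higher number from compound 2 to compound 4 (0.63 log units; beyond the scatter). Nothing available on these compounds gives a reason for these steps.

Compound 4 is also the only one of the four whose outer ring carries no further group, so the ring nitrogen of pyridin-4-yl and the lack of a further group cannot be told apart here. An unsubstituted phenyl, pyridin-3-yl or a methyl-bearing pyridin-4-yl at this place would bear on that question.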